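From a Cyclopropyl Ketone to a Bromophenyl Ketone

The compounds below may be only part of what the source reports. "The series", "measured", "known", "first", "only" and "open" are said of these compounds alone.

compound 1 `COc1cc(-c2nnc3n2NC(c2cccs2)C(C(=O)c2ccc(C)cc2)S3)cc(OC)c1OC`: 28400 nM
compound 2 `COc1cc(-c2nnc3n2NC(c2ccco2)C(C(=O)C2CC2)S3)cc(OC)c1OC`: > 100000 nM
compound 3 `COc1ccc(C(=O)C2Sc3nnc(-c4cc(OC)c(OC)c(OC)c4)n3NC2c2cccs2)cc1`: 49500 nM

Going by the values given here, in a functional assay on MCF7 cells (Homo sapiens) for cytotoxicity, read by MTT assay, with a stated time of 48 h (on this read-out higher numbers stand for weaker inhibition and lower numbers for stronger inhibition), compound 1 gives 28400 nM and compound 3 gives 49500 nM, the only measured step being a 1.7-fold higher number from compound 1 to compound 3 (0.24 log units; within the scatter). Compound 2 stands apart: in this assay it reached only a limit of the assay, > 100000 nM, not a number, as the limit of > 100000 nM in this assay, at which 1 of the 3 values shown sits, records.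

Compound 4 `COc1cc(-c2nnc3n2NC(c2ccco2)C(C(=O)c2cccc(Br)c2)S3)cc(OC)c1OC` has not yet been measured. It differs from compound 2 by 3-bromophenyl in place of cyclopropyl on a carbonyl carbon. Among the compounds with values here, no measured step covers this change; the one step known concerns a methoxy against a methyl and lies within the scatter. What the numbers show is that compound 1 and compound 3, which carry an aryl ketone, give finite values, while compound 2, with its cyclopropyl ketone, gives only a limit. Compound 4 is therefore expected to return a number near those two, estimated at 45000 nM with a range from 15000 nM to 150000 nM, an expected step of an at least 2.2-fold lower number from compound 2 to compound 4 (0.34 log units; beyond the scatter).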

Compound 4, half-maximal inhibitory concentration: 91800 nM
The estimate for compound 4 lay 2.0-fold (0.31 log units) below the measured number, within the range that was stated.
By their numbers in this assay, from the lowest: compounds 1, 3 and 4 (each within the scatter of the next, the first and the last beyond it). At a limit, above all of these: compound 2.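

With 3-bromophenyl in place of cyclopropyl on a carbonyl carbon, compound 4 gives a real number in this assay, 91800 nM. Going by these compounds, the step reads an at least 1.0-fold lower number from compound 2 to compound 4 (0.03 log units; that floor lies within the scatter), so it gives only a floor, and the true size of this change stays unknown. Compound 2 remains a limit, not a number: the limit of > 100000 nM in this assay, at which 1 of the 4 values shown sits.

The compounds shown leave open how a plain phenyl or a longer chain such as butyl would read in that place. They also leave open whether an amine on the 3-bromophenyl ring's place would change the number.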